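Changing the amide warhead on a cyano-bearing kinase inhibitor

A few compounds are considered here, and "the series" means these few. Any claim that something is new, unique, unknown or untested is made for them only; others in the source may bear on it.

Compound 2 `C=C(Cl)C(=O)Nc1cc(Nc2ncc(C#N)c(-c3cn(C)c4ccccc34)n2)c(OC)cc1N(C)CCN(C)C` shows the lower of the two numbers in a functional assay on NCI-H1975 cells (Homo sapiens) for antiproliferative activity, read by MTT assay, with a stated time of 72 h (on this read-out lower numbers stand for stronger inhibition and higher numbers for weaker inhibition), giving 1620 nM; compound 1 `CC/C=C\C(=O)Nc1cc(Nc2nccc(-c3cn(C)c4ccccc34)n2)c(OC)cc1N(C)CCN(C)C`, which differs in two places, gives 3860 nM. Compound 3 `CC/C=C\C(=O)Nc1cc(Nc2ncc(C#N)c(-c3cn(C)c4ccccc34)n2)c(OC)cc1N(C)CCN(C)C` keeps the nitrile and differs from compound 2 only by but-1-en-1-yl in place of 1-chloroethenyl on a carbonyl carbon. Compound 1 carries this same but-1-en-1-yl carbonyl group and gives 3860 nM, so a modest weakening is expected, estimated as a 1.6-fold higher number from compound 2 to compound 3 (0.21 log units; within the scatter) in this assay, possibly still inside the usual scatter. Compound 3 is therefore expected to give 2600 nM in this assay, with a range from 900 nM to 7500 nM.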

Compound 3, half-maximal inhibitory concentration: 1150 nM
Compound 3: the middle estimate sits 2.3-fold (0.35 log units) above what was measured, within the range that was stated.
By their numbers in this assay, from the lowest: compounds 3 and 2 (each within the scatter of the next); then compound 1.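

In this assay, but-1-en-1-yl in place of 1-chloroethenyl on a carbonyl carbon gives a 1.4-fold lower number from compound 2 to compound 3 (0.15 log units; within the scatter), so this position tolerates either group without a difference that can be read. Cyano in place of hydrogen on an aromatic carbon gives a 3.4-fold lower number from compound 1 to compound 3 (0.53 log units; beyond the scatter), which separates the nitrile from the carbonyl change for the first time and shows a modest gain in this assay. Nothing available explains either step. Going by these compounds, whether an amine or a longer chain on the carbonyl carbon would hold this level remains open. So does whether a chlorine or a methyl group on that aromatic carbon would match the nitrile.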